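A few compounds are considered here, and "the series" means these few. Any claim that something is new, unique, unknown or untested is made for them only; others in the source may bear on it.

For the measured compounds named here, compound 1 `O=C(N/N=C/c1ccc(F)cc1F)c1cc(-c2ccc(Cl)cc2)nn1Cc1ccc(Cl)nc1` is the weakest of the three measured members: in a functional assay on NCI-H23 cells (Homo sapiens) for antiproliferative activity, read by BrdU incorporation, with a stated time of 48 h (on this read-out higher numbers stand for weaker inhibition and lower numbers for stronger inhibition), compound 1 gives 7860 nM. Compound 2 `O=C(N/N=C/c1ccccc1O)c1cc(-c2ccc(Cl)cc2)nn1Cc1ccc(Cl)nc1` gives 270 nM and compound 3 `O=C(N/N=C/c1cccc(O)c1O)c1cc(-c2ccc(Cl)cc2)nn1Cc1ccc(Cl)nc1` gives 570 nM. Both measured steps from compound 1 are large, a 29-fold lower number from compound 1 to compound 2 (1.46 log units; beyond the scatter) and a 14-fold lower number from compound 1 to compound 3 (1.14 log units; beyond the scatter), and the step between the two hydroxylated compounds is modest, a 2.1-fold higher number from compound 2 to compound 3 (0.32 log units; beyond the scatter).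

Compound 4 `CC(C)(C)c1ccc(Cn2nc(-c3ccc(Cl)cc3)cc2C(=O)N/N=C/c2ccc(F)cc2F)cc1` differs from compound 1 at another place entirely: 4-(tert-butyl)phenyl in place of 6-chloropyridin-3-yl on a saturated chain carbon bound to an aromatic nitrogen. Going by the values given here, none of the measured steps touches this benzylic substituent; all three change only the aryl group on the carbon with a double bond to nitrogen, so the record gives no guide to the size or direction of this change. Compound 4 is therefore expected to stay close to compound 1, with a wide range: the estimate for compound 4 is 6000 nM, between 1500 nM and 25000 nM, a step of a 1.3-fold lower number from compound 1 to compound 4 (0.12 log units; within the scatter) that is expected to remain within the scatter.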

Compound 4, half-maximal inhibitory concentration: 21900 nM
Compound 4: middle estimate off by 3.7-fold (0.56 log units), on the low side; measured number inside the range.
By their numbers in this assay, from the lowest: compound 2; then compound 3; then compound 1; then compound 4.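

In this assay, for the compounds shown here, the step of a 2.8-fold higher number from compound 1 to compound 4 (0.45 log units; beyond the scatter) is the first measured change on the saturated chain carbon bound to an aromatic nitrogen, made with the 2,4-difluorophenyl group held fixed. It shows that this position affects the read-out: 4-(tert-butyl)phenyl in place of 6-chloropyridin-3-yl gives weaker inhibition, although the step is modest beside the large 29-fold lower number from compound 1 to compound 2 (1.46 log units; beyond the scatter) at the carbon with a double bond to nitrogen. No available measurement bears on the reason for this shift.

The compounds shown leave open whether the same exchange would have a similar effect with the 2-hydroxyphenyl group of compound 2 in place. They also leave open which part of the exchange matters, a question that a plain benzyl group or a 4-chlorobenzyl group at this position could help to separate.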